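Bromoacrylamide oxindoles: pyrrole to methylthiophene swap

The source may report more compounds than this note shows. Statements on the series, on what has been measured and on what is new or still open speak of the compounds shown alone.

Measured so far in a functional assay on HL-60 cells (Homo sapiens) for antiproliferative activity, read by MTT assay, with a stated time of 72 h; on this read-out lower numbers stand for stronger inhibition and higher numbers for weaker inhibition:
compound 1 `C#CC(=O)Nc1ccc2c(c1)/C(=C/c1ccc[nH]1)C(=O)N2` gives 5800 nM
compound 2 `C=C(Br)C(=O)Nc1ccc2c(c1)CC(=O)N2` gives 350 nM
compound 3 `C=C(Br)C(=O)Nc1ccc2c(c1)/C(=C/c1ccc[nH]1)C(=O)N2` gives 140 nM

Compound 3 stands lowest of the three; the nearest number is that of compound 2, and the step of a 41-fold lower number from compound 1 to compound 3 (1.62 log units; beyond the scatter) separates it from compound 1. Compound 4 `C=C(Br)C(=O)Nc1ccc2c(c1)/C(=C/c1sccc1C)C(=O)N2` differs from compound 3 in one place: 3-methylthiophen-2-yl in place of 1H-pyrrol-2-yl on a double-bonded chain carbon bound to a double-bonded ring carbon. Going by the values given here, no measured step changes this group, so the only guidance is that compounds 2 and 3 together suggest the group on the double-bonded chain carbon matters somewhat in this assay. The expected step of a 2.5-fold higher number from compound 3 to compound 4 (0.40 log units; beyond the scatter) is therefore uncertain and is set modest, toward a higher number. For compound 4 the estimate in this assay is 350 nM, with a range of 80 nM to 1500 nM.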

Compound 4, half-maximal inhibitory concentration: 13 nM
For compound 4 the middle estimate is 27-fold (1.43 log units) above the measured one; measured number below the stated range.
By their numbers in this assay, from the lowest: compound 4; then compound 3; then compound 2; then compound 1.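

Going by these compounds alone, with 3-methylthiophen-2-yl in place of 1H-pyrrol-2-yl, an 11-fold lower number from compound 3 to compound 4 (1.03 log units; beyond the scatter) in this assay is the first measured step on a double-bonded chain carbon bound to a double-bonded ring carbon. This place in the series therefore responds strongly to a change of group, here toward stronger inhibition. No evidence at hand bears on the reason for this step.

As far as these compounds go, the swap changes the ring hetero atom, the methyl and the donor count together, so the share of each stays open. From the compounds shown here alone, whether thiophen-2-yl without the methyl, or 3-ethylthiophen-2-yl, would hold the lower number also remains open.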